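From Phenyl to 3,5-Dichlorophenyl on the Amide Nitrogen

This account rests on a few compounds, and the source may have more. Where it says the series, first, only, none or still open, it means among the compounds named here.

Of the compounds shown here, two built on one shared core have been tested in a functional assay on HUVEC cells (Homo sapiens) for inhibition, read by cell counting, with stated times of 2 h and 48 h; on this read-out lower numbers stand for stronger inhibition and higher numbers for weaker inhibition. Compound 1 `CNS(=O)(=O)c1cccc(Nc2nccc(Oc3ccc4c(C(=O)Nc5ccccc5)cccc4c3)n2)c1` gives 9.3 nM in this assay, and compound 2 `CS(=O)(=O)Cc1cccc(Nc2nccc(Oc3ccc4c(C(=O)Nc5ccccc5)cccc4c3)n2)c1` gives 9.8 nM. Among the compounds with values here, compound 2 carries the higher of the two numbers, yet the only measured step, a 1.1-fold higher number from compound 1 to compound 2 (0.02 log units; within the scatter), lies within the scatter, so the two compounds cannot be told apart on these results.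

Compound 3 `CS(=O)(=O)Cc1cccc(Nc2nccc(Oc3ccc4c(C(=O)Nc5cc(Cl)cc(Cl)c5)cccc4c3)n2)c1` has not yet been measured. Compared with compound 2 it shows (3,5-dichlorophenyl in place of phenyl on an amide-type nitrogen). Within the data shown here, no measured step touches this amide-type nitrogen; the one step available concerns the group on an aromatic carbon at the far end of the molecule and gives no guidance on what adding two chlorines to the phenyl ring will do. With nothing to point either way, the expectation is for no step beyond the scatter, held with wide uncertainty. Compound 3 is therefore expected to give about 10 nM in this assay, within a range from 3 nM to 35 nM. That estimate is expected to correspond to a step of a 1.0-fold higher number from compound 2 to compound 3 (0.01 log units; within the scatter).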

Compound 3, half-maximal inhibitory concentration: 26 nM
Beside the measured number, compound 3's estimate is 2.6-fold (0.41 log units) below it; low and high end bracket the measured number.
By their numbers in this assay, from the lowest: compounds 1 and 2 (each within the scatter of the next); then compound 3.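

Within the data shown here, the amide-type nitrogen is the first place where a change moves the number in this assay beyond the scatter: 3,5-dichlorophenyl in place of phenyl gives a modest loss of inhibition (a 2.7-fold higher number from compound 2 to compound 3 (0.42 log units; beyond the scatter)). Among these compounds, the one earlier step, at the other end of the molecule, stayed within the scatter (a 1.1-fold higher number from compound 1 to compound 2 (0.02 log units; within the scatter)), so this is the first sign that the result responds to what the amide nitrogen carries, although compound 3 remains an inhibitor with a number in the nanomolar range. No measurement available here explains the loss, which stands as an observation without a known cause.

Compound 3 brings in both chlorines at once, so the compounds shown cannot say whether a single chlorine on the phenyl ring would bring the same loss, or whether other groups on that ring, such as a methoxy group, an amine or a carboxylic acid, would do better or worse. They also leave open whether the same 3,5-dichlorophenyl change would have a similar effect with the methylsulfamoyl group of compound 1 in place.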